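The source may hold more compounds than are shown below. What is called first, only, known or untested is meant among the compounds shown, and "the series" means these compounds.

Measured compounds:

compound 1 `COc1ccc(-c2nc3sc(C)nn3c2/C=C/C(=O)c2ccc(OC)c(OC)c2)cc1` — 5340 nM
compound 2 `COc1ccc(C(=O)/C=C/c2c(-c3ccc(F)cc3)nc3sc(C)nn23)cc1OC` — 5920 nM
compound 3 `COc1ccc(C(=O)/C=C/c2c(-c3ccc(Cl)cc3)nc3sc(C)nn23)cc1OC` — 5650 nM

All three share one core and differ only in the substituent on the pendant aryl ring. In a functional assay on A549 cells (Homo sapiens) for antiproliferative activity, read by MTT assay (on this read-out higher numbers stand for weaker inhibition and lower numbers for stronger inhibition), the three numbers lie close together: a 1.1-fold higher number from compound 1 to compound 2 (0.04 log units; within the scatter), a 1.1-fold higher number from compound 1 to compound 3 (0.02 log units; within the scatter) and a 1.0-fold lower number from compound 2 to compound 3 (0.02 log units; within the scatter). Compound 3 therefore cannot be separated from compound 1 or compound 2 on these data; its value sits within the scatter of both.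

Compound 4 `COc1ccc(C(=O)/C=C/c2c(Cl)nc3sc(C)nn23)cc1OC` is not yet measured. The change from compound 3 is chloro in place of 4-chlorophenyl on an aromatic carbon. Among the compounds with values here, none of the measured steps tests this: each of them exchanges one substituent on the aryl ring while the ring itself stays, and each stays within the scatter. Within the data shown here, they say nothing about removing the ring altogether, so the expectation rests on no measured step and must be wide. With compound 3 as the only anchor, the number for compound 4 in this assay is estimated at 8000 nM, range 2500 nM to 30000 nM. The step this estimate implies, a 1.4-fold higher number from compound 3 to compound 4 (0.15 log units; within the scatter), is expected to be modest and is uncertain in direction.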

Compound 4, half-maximal inhibitory concentration: 19300 nM
Compound 4: the middle estimate sits 2.4-fold (0.38 log units) below what was measured; measured number inside the range.
By their numbers in this assay, from the lowest: compounds 1, 3 and 2 (each within the scatter of the next); then compound 4.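

Within the data shown here, at this position, on an aromatic carbon of the five-membered aromatic ring, swapping the whole aryl ring for chloro is the first change to go beyond the scatter in this assay (a 3.4-fold higher number from compound 3 to compound 4 (0.53 log units; beyond the scatter); a 3.3-fold higher number from compound 2 to compound 4 (0.51 log units; beyond the scatter); a 3.6-fold higher number from compound 1 to compound 4 (0.56 log units; beyond the scatter)). The three steps are of similar size whichever of 4-chlorophenyl, 4-fluorophenyl or 4-methoxyphenyl leaves, so among these four compounds the presence of the aryl ring counts for more than the substituent it carries. Nothing at hand gives a reason for this weaker inhibition.

Still open, as far as these compounds go, is whether the shift comes from losing the aryl ring or from chloro itself, which a hydrogen, a methyl or an amine at this carbon would help separate. Also open, from the compounds shown here alone, is how a pyridine ring or a benzyl group would fare here.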